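Replacing Ethylsulfonyl with a Urea-Type Carbamoyl Group

A few compounds are considered here, and "the series" means these few. Any claim that something is new, unique, unknown or untested is made for them only; others in the source may bear on it.

- compound 1 (`C=CS(=O)(=O)N1CCN(c2ncnc3sc(-c4ccc(OC)nc4)cc23)CC1`): 9270 nM
- compound 2 (`CCS(=O)(=O)N1CCN(c2ncnc3sc(-c4ccc(N5CCN(C)CC5)cc4)cc23)CC1`): 7330 nM

In a functional assay on MDA-MB-231 cells (Homo sapiens) for antiproliferative activity, read by MTT assay, with a stated time of 48 h (a higher number here means a weaker inhibitor, a lower number a stronger inhibitor), compound 2 gives 7330 nM and stands within the usual scatter of compound 1 (9270 nM). Compound 3 (`COc1ccc(NC(=O)N2CCN(c3ncnc4sc(-c5ccc(N6CCN(C)CC6)cc5)cc34)CC2)cc1`) keeps the rest of compound 2 but carries (4-methoxyphenyl)carbamoyl in place of ethylsulfonyl on an amine nitrogen in a ring. Going by the values given here, the two measured compounds differ in more than one place, so no measured step speaks directly to this change. In this assay a small shift toward a stronger inhibitor is expected, not clearly beyond the scatter, and the uncertainty runs in both directions. The expected change is a 1.8-fold lower number from compound 2 to compound 3 (0.26 log units; within the scatter) by this estimate. Compound 3 is estimated at 4000 nM with an expected range from 900 nM to (15000 nM).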

Compound 3, half-maximal inhibitory concentration: 20900 nM
Compound 3: the middle estimate sits 5.2-fold (0.72 log units) below what was measured; measured number above the stated range.
By their numbers in this assay, from the lowest: compounds 2 and 1 (each within the scatter of the next); then compound 3.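

In this assay the exchange on the amine nitrogen in the ring gives a 2.9-fold higher number from compound 2 to compound 3 (0.46 log units; beyond the scatter) with the rest of compound 2 unchanged, the first reading of a single change in the compounds shown. It shows that this position is not indifferent to its substituent: here, (4-methoxyphenyl)carbamoyl gives a weaker inhibitor than ethylsulfonyl. Nothing shown explains the direction of this shift.

The step brings in the six-membered aromatic ring, the methoxy group and the hydrogen-bond donor together, so the compounds shown do not separate their contributions. Also open, on these data alone, is how a smaller group on this same nitrogen, such as acetyl or methylcarbamoyl, would compare with ethylsulfonyl and with (4-methoxyphenyl)carbamoyl.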